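The compounds below may be only part of what the source reports. "The series", "measured", "known", "first", "only" and "open" are said of these compounds alone.

Measured compounds:
compound 1, `CC1(c2ccc(Br)cc2)CC(S(=O)(=O)c2ccc(F)cc2)=C(c2ccc(/C(N)=N\O)cc2)O1`, with 10500 nM in an ADME assay on J774.A1 cells (Mus musculus) for cytotoxicity, read by MTT assay, with a stated time of 72 h; a higher number here means that more compound is tolerated, a lower number that less compound is tolerated
compound 2, `CC1(Cc2ccccc2)CC(S(=O)(=O)c2cccc(C(F)(F)F)c2)=C(c2ccc(/C(N)=N\O)cc2)O1`, with 14500 nM in this assay
compound 3, `CC1(Cc2ccccc2)CC(S(=O)(=O)c2cccc(F)c2)=C(c2ccc(/C(N)=N\O)cc2)O1`, with 28300 nM in this assay

Compound 1 gives the lowest of the three numbers in this assay. Its nearest neighbour is compound 2, whose value lies within the scatter of that of compound 1, while compound 3 stands further off, beyond the scatter. Among the measured compounds shown here, the only step between two measured compounds that differ in a single place is a 2.0-fold higher number from compound 2 to compound 3 (0.29 log units; within the scatter), and it concerns the group on the sulfonyl-bearing ring rather than the position changed here.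

Compound 4, `CC1(c2ccc(-c3ccccc3C#N)cc2)CC(S(=O)(=O)c2ccc(F)cc2)=C(c2ccc(/C(N)=N\O)cc2)O1`, differs from compound 1 by 2-cyanophenyl in place of bromo on an aromatic carbon. For the measured compounds named here, no measured pair shows the same change, so the step from compound 1 to compound 4 is not informed by any directly comparable data. Going by the values given here, the one step that is known is small, and the three measured values lie within a narrow band; on that basis one expects no step beyond the scatter in this assay, in either direction, and a wide range to reflect the lack of a precedent.

The estimate for compound 4 in this assay is therefore 9000 nM, with a range from 3500 nM to 25000 nM. This expectation corresponds to a 1.2-fold lower number from compound 1 to compound 4 (0.07 log units; within the scatter).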

Compound 4, half-maximal cytotoxic concentration: 9290 nM
The estimate for compound 4 lay 1.0-fold (0.01 log units) below the measured number; the measured number falls inside the stated range.
By their numbers in this assay, from the lowest: compounds 4, 1, 2 and 3 (each within the scatter of the next, the first and the last beyond it).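

In this assay, the exchange on an aromatic carbon para to a large group gives a 1.1-fold lower number from compound 1 to compound 4 (0.05 log units; within the scatter), so adding an aromatic ring and a nitrile at this position leaves the number within the scatter. Among the compounds shown here, the earlier compounds offered only one step, a 2.0-fold higher number from compound 2 to compound 3 (0.29 log units; within the scatter), which concerns the group on the sulfonyl-bearing ring and says nothing about this position; the new step is the first reading of a change here, and it shows that bromo can give way to the larger 2-cyanophenyl without a step beyond the scatter. Nothing available here accounts for this result, so the finding stands as an observation only.

This single exchange leaves open whether the added ring or its nitrile matters more, since plain phenyl in place of bromo would be needed to separate the two. It also leaves open whether an amine, a carboxylic acid or a longer alkyl chain at this position would likewise stay within the scatter of compound 1 in this assay.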